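The source may report more compounds than this note shows. Statements on the series, on what has been measured and on what is new or still open speak of the compounds shown alone.

Compound 1, `CCCCN(C(=O)c1ccc(C(F)(F)F)cc1)c1nnc(-c2cccc3[nH]ccc23)s1`, gives 43.2 uL/min in an ADME assay on microsomes from liver (Rattus norvegicus) for metabolic stability, read by LC-MS, tested at 0.5 uM; a higher number here means faster removal of the compound, a lower number slower removal.
Compound 2, `CCCCN(C(=O)c1ccc(C(F)(F)F)cc1)c1nnc(-c2ccc(CN(C)C)cc2)s1`, gives 539 uL/min in this assay.

Compound 2 stands highest of the two numbers, separated from compound 1 by a 12-fold higher number from compound 1 to compound 2 (1.10 log units; beyond the scatter). Compound 3, `CCCCN(C(=O)c1ccc(C(F)(F)F)cc1)c1nnc(-c2ccc(CO)cc2)s1`, differs from compound 2 by hydroxy in place of dimethylamino on a saturated chain carbon bound to an aromatic carbon. For the measured compounds named here, the single measured step, a 12-fold higher number from compound 1 to compound 2 (1.10 log units; beyond the scatter), concerns a different part of the molecule, so it offers no direct guide to this change; it shows only that numbers in this assay can shift widely. Going by the values given here, no measured compound carries hydroxy at this place, so the expectation rests on compound 2 alone, and compound 3 is expected to give a lower number, a 3.6-fold lower number from compound 2 to compound 3 (0.56 log units; beyond the scatter). Compound 3 is estimated at 150 uL/min, within 50 uL/min to 450 uL/min.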

Compound 3, intrinsic clearance in a liver preparation (reported as CLH), per the amount of preparation that the assay uses: 279 uL/min
Compound 3: the middle estimate sits 1.9-fold (0.27 log units) below what was measured; the measured number falls inside the stated range.
By their numbers in this assay, from the lowest: compound 1; then compounds 3 and 2 (each within the scatter of the next).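

In this assay, hydroxy in place of dimethylamino on this saturated chain carbon gives a 1.9-fold lower number from compound 2 to compound 3 (0.29 log units; within the scatter) and so makes no clear difference. With hydroxy on that carbon, 4-(hydroxymethyl)phenyl in place of 1H-indol-4-yl still gives a 6.5-fold higher number from compound 1 to compound 3 (0.81 log units; beyond the scatter) and stays beyond the scatter, as the change to the dimethylamino compound did. Nothing available here explains these numbers. Open, from the compounds shown here alone, is whether a carboxylic acid or a longer chain at this place would shift the number in this assay beyond the scatter.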